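This account rests on a few compounds, and the source may have more. Where it says the series, first, only, none or still open, it means among the compounds named here.

- Compound 1 `CC(C)(C)OC(=O)N1C[C@@H](n2cc(-c3ccc(N)nc3)nn2)C[C@H]1C(=O)Nc1ccc(Cl)c(C(F)(F)F)c1`: 4710 nM
- Compound 2 `Nc1ccc(-c2cn([C@@H]3CN[C@H](C(=O)Nc4ccc(Cl)c(C(F)(F)F)c4)C3)nn2)cn1`: 10400 nM
- Compound 3 `O=C(Nc1n[nH]c2cc(-c3cn([C@@H]4CN[C@H](C(=O)Nc5ccc(Cl)cc5Cl)C4)nn3)ccc12)C1CC1`: 5340 nM

In a functional assay on K562 cells (Homo sapiens) for inhibition, read by MTT assay, with a stated time of 48 h (a higher number here means a weaker inhibitor, a lower number a stronger inhibitor), compound 2 stands at 10400 nM, the highest of the three numbers, though within the scatter of compound 3. Compound 4 `Nc1nc2ccc(-c3cn([C@@H]4CN[C@H](C(=O)Nc5ccc(Cl)c(C(F)(F)F)c5)C4)nn3)nc2s1` departs from compound 2 on an aromatic carbon of the five-membered aromatic ring with 3 nitrogen: a group of 10 heavy atoms (6 carbon, 3 nitrogen, 1 sulfur; one five-membered aromatic ring with 2 hetero atoms, one six-membered aromatic ring with 1 hetero atom) in place of a group of 7 heavy atoms (5 carbon, 2 nitrogen; one six-membered aromatic ring with 1 hetero atom), on an aromatic carbon. Among the compounds with values here, the only measured step, a 2.2-fold higher number from compound 1 to compound 2 (0.34 log units; beyond the scatter), is modest and concerns the ring amine nitrogen, so it does not bear directly on this change. Compound 3 at 5340 nM carries another group on that carbon but also differs elsewhere, so it offers only loose guidance. No change beyond the scatter is therefore expected, and the expected step is a 1.5-fold lower number from compound 2 to compound 4 (0.17 log units; within the scatter). For compound 4 the estimated value is 7000 nM, with an expected range of 2500 nM to 20000 nM.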

Compound 4, half-maximal inhibitory concentration: 26200 nM
The estimate for compound 4 lay 3.7-fold (0.57 log units) below the measured number; the whole stated range lies below it.
By their numbers in this assay, from the lowest: compounds 1, 3 and 2 (each within the scatter of the next, the first and the last beyond it); then compound 4.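

In this assay, putting the group with one five-membered and one six-membered aromatic ring in place of 6-aminopyridin-3-yl gives a 2.5-fold higher number from compound 2 to compound 4 (0.40 log units; beyond the scatter). Within the data shown here, this is the first step read at this aromatic carbon, and it shows that the position does not take this larger group without a modest loss, whereas the earlier step concerned only the ring amine nitrogen. Nothing measured here gives a reason for this step. The compounds shown leave open how a plain phenyl or a carboxylic acid on this carbon would read, and whether the same step holds with tert-butoxycarbonyl on the ring amine nitrogen.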